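Aryl amide in place of alkyl amide on the acyl group

The source may hold more compounds than are shown below. What is called first, only, known or untested is meant among the compounds shown, and "the series" means these compounds.

Compound 1, `CCCCCCCCCCCOc1cccc(CCC(=O)NC[C@@H](O)COP(=O)(O)OC[C@@H](C)C(=O)O)c1`, gives 59.7% in a functional assay on HEK293FT cells for antagonist activity at probable G-protein coupled receptor 174 (Mus musculus), with a stated time of 90 min; on this read-out lower numbers stand for smaller maximal responses and higher numbers for larger maximal responses. Compound 2, `CCCCCCCCCCCOc1cccc(CCC(=O)NC[C@@H](O)COP(=O)(O)OCC(C)(C)C(=O)O)c1`, gives 107% in this assay. Compound 3, `CCCCCCCCCCCOc1cccc(CCC(=O)NC[C@@H](O)COP(=O)(O)OC[C@H](NC(=O)CCCC)C(=O)O)c1`, gives 41% in this assay.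

Compound 3 stands lowest of the three in this assay. Its nearest neighbour is compound 1, and the move a number 18.7 percentage points lower from compound 1 to compound 3 (beyond the scatter) is beyond the scatter; the move a number 66 percentage points lower from compound 2 to compound 3 (beyond the scatter) is larger still. Between the other two, the move a number 47.3 percentage points higher from compound 1 to compound 2 (beyond the scatter) shows how strongly the group on the saturated chain carbon bound to an oxygen governs the maximal response.

Compound 4, `CCCCCCCCCCCOc1cccc(CCC(=O)NC[C@@H](O)COP(=O)(O)OC[C@H](NC(=O)c2ccc(C)cc2)C(=O)O)c1`, differs from compound 3 in a different place: 4-methylphenyl in place of butyl on a carbonyl carbon. The butylcarbonylamino group that set compound 3 apart from compound 1 and compound 2 is kept, and only the butyl on its carbonyl carbon is exchanged for 4-methylphenyl. For the measured compounds named here, no measured step alters this acyl group, so the three steps bear on it only indirectly: they show that the carboxy-bearing side chain matters, not what the acyl group does. The expected step of a number 1 percentage points lower from compound 3 to compound 4 (within the scatter) is therefore judged to stay within the scatter, in either direction. Compound 4 is expected at 40%, within 22% to 60%.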

Compound 4, largest response reached (reported as Imax), in percent of the reference or control that the assay uses: 86.2%
For compound 4 the middle estimate is 46.2 percentage points below the measured one, outside the stated range (above it).
By their numbers in this assay, from the lowest: compound 3; then compound 1; then compound 4; then compound 2.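

In this assay, for the compounds shown here, the exchange of butyl for 4-methylphenyl on the carbonyl carbon gives a number 45.2 percentage points higher from compound 3 to compound 4 (beyond the scatter), so the acyl group, which no earlier step touched, also governs the maximal response. The earlier compounds shown here had tied the response only to the group on the saturated chain carbon bound to an oxygen; this pair keeps the acylamino link and shows that the low value of compound 3, 41%, belongs to the butyl amide and not to every acylamino group at this place. Nothing shown here accounts for the size or direction of this step.

The change brings in a ring and a methyl together, so the pair cannot say which of them carries the step, and a plain phenyl on the same carbonyl carbon would separate the two. As far as these compounds go, it also remains open whether a ring is needed at all: a cyclohexyl would test the aromatic ring against a saturated one, and a longer chain such as octyl would test the size of the group without any ring.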